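Swapping the side group on compound 3's chain carbon

The source may report more compounds than this note shows. Statements on the series, on what has been measured and on what is new or still open speak of the compounds shown alone.

Measured compounds:
compound 1 `Cn1c(-c2ccc(NC(=O)CCl)cc2)nc(-c2ccccc2)c1-c1ccccc1` with 15.2%
compound 2 `Cn1cnnc1SCC(=O)Nc1ccc(-c2nc(-c3ccccc3)c(-c3ccccc3)n2C)cc1` with 61.2%
compound 3 `Cn1ccnc1SCC(=O)Nc1ccc(-c2nc(-c3ccccc3)c(-c3ccccc3)n2C)cc1` with 32.4%

All three share one core and differ only in the group on a saturated chain carbon bound to a carbonyl carbon. In a functional assay on MCF7 cells (Homo sapiens) for cytotoxicity, read by MTT assay, with a stated time of 24 h, tested at 16 ug/mL (on this read-out higher numbers stand for a stronger effect at the one concentration tested and lower numbers for a weaker effect), compound 3 stands second of the three numbers: it lies above compound 1 by a number 17.2 percentage points higher from compound 1 to compound 3 (beyond the scatter) and below compound 2 by a number 28.8 percentage points lower from compound 2 to compound 3 (beyond the scatter).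

Compound 4 `CN1CCN(CC(=O)Nc2ccc(-c3nc(-c4ccccc4)c(-c4ccccc4)n3C)cc2)CC1` has not been measured. Its change from compound 3 is 4-methylpiperazin-1-yl in place of (1-methyl-1H-imidazol-2-yl)sulfanyl on a saturated chain carbon bound to a carbonyl carbon. Among the measured compounds shown here, no measured step swaps a ring-on-sulfur group for a ring joined directly through nitrogen, so no step bears on it closely. The nearest are a number 46 percentage points higher from compound 1 to compound 2 (beyond the scatter) and a number 17.2 percentage points higher from compound 1 to compound 3 (beyond the scatter), which show that the group at this place moves the number by a modest to large amount. For the measured compounds named here, with no direct precedent, a step of either direction is possible, and none beyond the scatter is expected: a number 2.4 percentage points lower from compound 3 to compound 4 (within the scatter). Compound 4 is therefore expected to give 30%, within 10% to 55%.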

Compound 4, a percentage reported as activity, at one concentration (the size of the read-out at that concentration, not a potency): 30.1%
Estimate against measurement, compound 4: 0.1 percentage points below; low and high end bracket the measured number.
By their numbers in this assay, from the lowest: compound 1; then compounds 4 and 3 (each within the scatter of the next); then compound 2.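

In this assay, moving from (1-methyl-1H-imidazol-2-yl)sulfanyl to 4-methylpiperazin-1-yl gives a number 2.3 percentage points lower from compound 3 to compound 4 (within the scatter), so at this position a non-aromatic ring without sulfur does no differently from this sulfur-linked aromatic ring. The same group still gives a number 14.9 percentage points higher from compound 1 to compound 4 (beyond the scatter), which shows that a rise over chloro does not depend on a sulfur link or an aromatic ring, while a number 31.1 percentage points lower from compound 2 to compound 4 (beyond the scatter) leaves the (4-methyl-4H-1,2,4-triazol-3-yl)sulfanyl group alone at the top of the four. No measurement shown here explains these differences. Still open, going by these compounds, is whether a morpholin-4-yl or a dimethylamino group on this chain carbon would give a number close to that of the piperazine. Also open, on these data alone, is whether the triazole ring would keep its high number without the sulfur.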